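This account rests on a few compounds, and the source may have more. Where it says the series, first, only, none or still open, it means among the compounds named here.

In an assay on COS-7 cells for inhibition of patatin-like phospholipase domain-containing protein 2 (Mus musculus), tested at 200 uM (on this read-out higher numbers stand for more inhibition at the one concentration tested (going by the name of the read-out) and lower numbers for less inhibition), compound 3 `CCOC(=O)c1cccc(-c2ccc(OCC)c([N+](=O)[O-])c2)c1` gives 44%. That number stands level with compound 2 `CCOC(=O)c1ccc(-c2ccc(OCC)cc2)[nH]1`, which gives 44%, and the two are together the lowest of the three measured; compound 1 `CCOC(=O)c1cccc(-c2ccc(OCC)cc2)c1` gives 87%. Going by the values given here, the only single step measured leads to compound 3: a number 43 percentage points lower from compound 1 to compound 3 (beyond the scatter). Compound 4 `CCOC(=O)c1cccc(-c2ccc(OCC)c(N)c2)c1` differs from compound 3 as follows: amino in place of nitro on an aromatic carbon. Among the compounds with values here, no measured step shows an amino group entering at this position, so the change can only be read against the step in which nitro entered there and lowered the read-out strongly. Some recovery toward compound 1 is therefore expected, though not all of it. The estimate for compound 4 in this assay is 62%, with a range from 38% to 85%, an expected step of a number 18 percentage points higher from compound 3 to compound 4 (beyond the scatter).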

Compound 4, a percentage reported as inhibition, at one concentration (the size of the read-out at that concentration, not a potency): 59%
Estimate against measurement, compound 4: 3 percentage points above, and the stated range covers the measured number.
By their numbers in this assay, from the lowest: compounds 2 and 3 (each within the scatter of the next); then compound 4; then compound 1.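

Replacing nitro with amino at this place, ortho to an ethoxy group, gives a number 15 percentage points higher from compound 3 to compound 4 (beyond the scatter) in this assay and so shows that the read-out here depends on which group enters. Amino still falls short of hydrogen, with a number 28 percentage points lower from compound 1 to compound 4 (beyond the scatter) as the step, so both groups placed here stand lower than hydrogen does. The compounds shown leave open whether fluorine, a methyl group or an acetamide would stay closer to hydrogen at this place, and whether the same change would hold on the core of compound 2. No evidence is at hand that explains these steps.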